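The compounds below may be only part of what the source reports. "The series", "measured", "known", "first", "only" and "open" are said of these compounds alone.

Of the compounds shown here, three of a shared core have been tested in a functional assay on SK-BR-3 cells (Homo sapiens) for cytotoxicity, read by MTT assay, with a stated time of 72 h; a lower number here means that less compound is needed, a higher number that more compound is needed for the effect. Compound 1 `CCc1cccc2c(O)c(-c3occ(C)c3C(=O)O)ccc12` gives 1 ug/mL in this assay. Compound 3 `CCOc1c(-c2occ(C)c2C(=O)OC)ccc2c(CC)cccc12` gives 1.9 ug/mL. Compound 2 `CCc1cccc2c(OC)c(-c3occ(C)c3C(=S)OC)ccc12` gives 6.3 ug/mL, the highest of the three numbers, so that more of compound 2 is needed for the same effect than of compound 1 or compound 3, and both of those gaps lie beyond the usual scatter of the method.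

Compound 4 `CCc1cccc2c(OC)c(-c3occ(C)c3COCC(F)(F)F)ccc12` has not yet been measured. It differs from compound 2 in one place: a group of 7 heavy atoms (3 carbon, 1 oxygen, 3 fluorine; no ring) in place of a group of 4 heavy atoms (2 carbon, 1 oxygen, 1 sulfur; no ring), on an aromatic carbon. The (2,2,2-trifluoroethoxy)methyl group takes the position on the five-membered aromatic ring that in compound 2 carries the smaller sulfur-containing group.

For the measured compounds named here, no pair of measured compounds shows this particular change, so there is no step from the data itself to lean on. The three numbers seen so far all sit within a narrow band, and nothing among them points to a large move in either direction for compound 4. In this assay compound 4 is therefore expected to land close to compound 2, with an estimated step of a 1.3-fold lower number from compound 2 to compound 4 (0.10 log units; within the scatter) that may well fall within the scatter. The estimate for compound 4 is 5 ug/mL, with a range from 1.5 ug/mL to 18 ug/mL.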

Compound 4, concentration for half-maximal effect: 5.3 ug/mL
The estimate for compound 4 lay 1.1-fold (0.03 log units) below the measured number; low and high end bracket the measured number.
By their numbers in this assay, from the lowest: compounds 1 and 3 (each within the scatter of the next); then compounds 4 and 2 (each within the scatter of the next).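

In this assay, for the compounds shown here, this is the first change that can be read in one place, and the step is a 1.2-fold lower number from compound 2 to compound 4 (0.08 log units; within the scatter). On this aromatic carbon of the five-membered ring, the sulfur-containing group can thus give way to the (2,2,2-trifluoroethoxy)methyl group with no change that rises above the scatter, even though the entering group has more heavy atoms, carries fluorine and no sulfur, and counts fewer hydrogen-bond acceptors. Nothing measured here bears on why these two very different groups give matching numbers.

A single step at a single position cannot show how widely this position accepts other groups: an amine, an amide or a longer ether chain on the same carbon might keep the number where it is or might move it well beyond the scatter. Also open, on these data alone, is whether the same swap would give a matching number on the core of compound 1 or compound 3, where the neighbouring ring carries a different oxygen substituent.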